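A few compounds are considered here, and "the series" means these few. Any claim that something is new, unique, unknown or untested is made for them only; others in the source may bear on it.

Measured so far:
- compound 1 `O=C(O)c1cc(-c2cccc(COc3ccc4c(c3)CN(C3CCCC3)C4=O)c2)ccc1O`: 0.102 uM
- compound 2 `O=C(O)c1cc(-c2cccc(COc3ccc4c(=O)n(C5CC5)sc4c3)c2)ccc1Cl`: 0.664 uM

In an assay on HEK293 cells for positive allosteric modulation of metabotropic glutamate receptor 2 (Rattus norvegicus), read by thallium flux (a higher number here means that more compound is needed for the effect, a lower number that less compound is needed), compound 1 gives 0.102 uM, the lowest of the two numbers in hand. In this assay, going by the values given here, compound 2 gives 0.664 uM, a higher number, and the gap between the two lies beyond the scatter; since the two compounds differ in more than one place, no single step is drawn between them.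

Compound 3 `COc1ccc(C(=O)O)cc1-c1cccc(COc2ccc3c(c2)CN(C2CCCC2)C3=O)c1` is not yet measured. It differs from compound 1 in one place: 5-carboxy-2-methoxyphenyl in place of 3-carboxy-4-hydroxyphenyl on an aromatic carbon. The 3-carboxy-4-hydroxyphenyl of compound 1 carries two hydrogen-bond donors, the 5-carboxy-2-methoxyphenyl of compound 3 only one, and the carboxy sits at a different position of the ring that enters.

No step within the shown compounds reports this kind of change, so the expectation rests on compound 1 alone. The step from compound 1 to compound 3 is expected to go toward a higher number, of a size a 4.9-fold higher number from compound 1 to compound 3 (0.69 log units; beyond the scatter), beyond the scatter, though with wide uncertainty. Compound 3 is therefore estimated at 0.5 uM, within a range from 0.12 uM to 2.5 uM.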

Compound 3, concentration for 90% of the maximal effect: 0.248 uM
For compound 3 the middle estimate is 2.0-fold (0.30 log units) above the measured one, within the range that was stated.
By their numbers in this assay, from the lowest: compound 1; then compound 3; then compound 2.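

In this assay, going by these compounds alone, the exchange of 3-carboxy-4-hydroxyphenyl for 5-carboxy-2-methoxyphenyl, on an aromatic carbon of a six-membered aromatic ring of carbon only, gives a 2.4-fold higher number from compound 1 to compound 3 (0.39 log units; beyond the scatter) and is the first single-place step available. The step is modest in size, so on the core of compound 1 this position accepts both a different placing of the carboxy and fewer hydrogen-bond donors on the ring without a large shift, but these two changes arrive together and this one step cannot separate them. No measurement at hand speaks to why the number moves.

Still open, on these data alone, is which part of the exchange carries the step, and whether an ethoxy group or a fluorine in place of the methoxy would leave the number where it is. All compounds shown carry a carboxylic acid on this ring, so it also remains open how a tetrazole or a primary amide would read at that place, and whether the same exchange gives a step of similar size on the core of compound 2.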